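One Fluorine Fewer on the Difluoroethyl Chain

A few compounds are considered here, and "the series" means these few. Any claim that something is new, unique, unknown or untested is made for them only; others in the source may bear on it.

Compound 1 `Cn1c(-c2ccccc2C(F)(F)F)nnc1C12CCC(CNS(C)(=O)=O)(CC1)CC2`: in an assay on CHO-K1 cells for inhibition of 11-beta-hydroxysteroid dehydrogenase type 2 (Homo sapiens), read by scintillation proximity assay (a lower number here means a stronger inhibitor, a higher number a weaker inhibitor), compound 1 gives > 4000 nM, which is a limit of the assay and not a number.
Compound 2 `CCCCCC12CCC(c3nnc(-c4ccccc4C(F)(F)F)n3C)(CC1)CC2`: in this assay compound 2 gives 1300 nM.
Compound 3 `Cn1c(-c2ccccc2C(F)(F)F)nnc1C12CCC(CCCC(C)(F)F)(CC1)CC2`: in this assay compound 3 gives > 4000 nM, again a limit of the assay.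

Compound 3 therefore stands at the weak end of what has been measured, at the limit of > 4000 nM in this assay, at which 2 of the 3 values shown sit. Within the data shown here, the only numbered compound is compound 2, and the step of an at least 3.0-fold higher number from compound 2 to compound 3 (0.48 log units; beyond the scatter) shows that 1,1-difluoroethyl in place of ethyl, three bonds along the chain from the saturated ring carbon, costs at least a modest amount of potency. The step that the two limits leave unreadable from compound 1 to compound 3 is unreadable because both ends sit at limits.

Compound 4 `CC(F)CCCC12CCC(c3nnc(-c4ccccc4C(F)(F)F)n3C)(CC1)CC2` differs from compound 3 by hydrogen in place of fluoro on a saturated chain carbon bound to a fluorine atom and two saturated chain carbons. This removes one of the two fluorines that separate compound 3 from compound 2, so the relevant evidence is the step of an at least 3.0-fold higher number from compound 2 to compound 3 (0.48 log units; beyond the scatter), and a partial return toward compound 2 is expected. Compound 4 is therefore estimated to give 2500 nM in this assay, within 800 nM to 8000 nM, which amounts to an expected step of an at least 1.6-fold lower number from compound 3 to compound 4 (0.20 log units; that floor lies within the scatter), though a reading at the limit again remains quite possible.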

Compound 4, half-maximal inhibitory concentration: 1300 nM
The estimate for compound 4 lay 1.9-fold (0.28 log units) above the measured number; the range from low to high includes it.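

In this assay, the second fluorine on this saturated chain carbon is what separates the two fluorinated chains: hydrogen in place of fluoro gives an at least 3.0-fold lower number from compound 3 to compound 4 (0.48 log units; beyond the scatter). The first fluorine shows no such cost, since fluoro in place of hydrogen at the same carbon gives no change at the digits printed from compound 2 to compound 4 (within the scatter), so among compounds 2, 3 and 4 the loss belongs to 1,1-difluoroethyl and not to 1-fluoroethyl. The change from methanesulfonamido to 3-fluorobutyl gives an at least 3.0-fold lower number from compound 1 to compound 4 (0.48 log units; beyond the scatter), which shows that a fluorinated chain can still stand clear of the weak end of this series, with compound 3 as the one fluorinated chain that goes against this.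

From the compounds shown here alone, how much the second fluorine costs stays open, as compounds 1 and 3 give only a limit and not a number: the limit of > 4000 nM in this assay, at which 2 of the 4 values shown sit. The compounds shown also leave open whether a hydroxyl group or an amine at this chain carbon, or a longer chain carrying the single fluoro, would read like compound 4 or fall back to the limit.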